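Adding a Second Chlorine to a Fused Core

The source may report more compounds than this note shows. Statements on the series, on what has been measured and on what is new or still open speak of the compounds shown alone.

Three measured compounds share a fused two-ring core joined to a benzyl group that carries a chloromethyl substituent. In a functional assay on NCI-H226 cells (Homo sapiens) for cytotoxicity, read by sulforhodamine B assay, with a stated time of 48 h (a higher number here means a weaker inhibitor of growth, a lower number a stronger inhibitor of growth), compound 1 `ClCc1ccc(Cn2cnc3c(Cl)ncnc32)cc1` gives 1580 nM. Compound 3 `ClCc1ccc(Cn2cnc3c(Cl)nc(Cl)nc32)cc1`, which carries one more chloro group on the core, gives 3550 nM. Compound 2 `ClCc1cccc(Cn2cnc3ncnc(Cl)c32)c1`, whose benzyl group is attached at a different position, gives 3160 nM, the second highest of the three numbers; its gaps to compound 3 and to compound 1 both lie within the scatter, so no order among them can be claimed.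

Compound 4 `ClCc1cccc(Cn2cnc3nc(Cl)nc(Cl)c32)c1` has not yet been measured. It differs from compound 2 by chloro in place of hydrogen on an aromatic carbon. Among the compounds with values here, one measured step bears directly on this change: a 2.2-fold higher number from compound 1 to compound 3 (0.35 log units; beyond the scatter), where the same chloro group enters the same place on the core. A step of similar size, upward, is therefore expected in this assay, because a 2.2-fold higher number from compound 1 to compound 3 (0.35 log units; beyond the scatter) was modest but beyond the scatter. Compound 4 is expected to give about 6500 nM, with a likely range from 3200 nM to 13000 nM. That estimate means a step of a 2.1-fold higher number from compound 2 to compound 4 (0.31 log units; beyond the scatter).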

Compound 4, concentration for 50% growth inhibition: 1280 nM
For compound 4 the middle estimate is 5.1-fold (0.71 log units) above the measured one; measured number below the stated range.
By their numbers in this assay, from the lowest: compounds 4, 1, 2 and 3 (each within the scatter of the next, the first and the last beyond it).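

In this assay the chloro group on the aromatic carbon between two ring nitrogen atoms gives a 2.5-fold lower number from compound 2 to compound 4 (0.39 log units; beyond the scatter) and so moves the number the opposite way from the earlier step. The effect of this change therefore cannot be carried from one of these cores to the other, not even in direction. The earlier pair alone could not show this, and the two steps now disagree clearly: the same change on two cores in this assay, a 2.2-fold higher number (0.35 log units; beyond the scatter) from compound 1 to compound 3 and a 2.5-fold lower number (0.39 log units; beyond the scatter) from compound 2 to compound 4, 5.5-fold (0.74 log units) apart, beyond the scatter of two such steps.

The two pairs differ both in how the benzyl group is attached to the core and in where the chloromethyl group sits on it, and these compounds cannot tell which of the two goes with the reversal. Also open, from the compounds shown here alone, is how an amine or a methoxy group on the same carbon would behave on either core.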